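Series notes on cytotoxicity: tert-butyl to amino swap

The source may report more compounds than this note shows. Statements on the series, on what has been measured and on what is new or still open speak of the compounds shown alone.

The series is read in an ADME assay on Raji cells (Homo sapiens) for cytotoxicity, with a stated time of 72 h; on this read-out higher numbers stand for an effect only at larger amounts of compound and lower numbers for an effect already at smaller amounts. Compound 1 `Cc1cc(NC(=O)Nc2ccc(C(C)(C)C)cc2)c2ccccc2n1` reaches only the limit of the assay there, giving > 25000 nM. Compound 2 `CSc1ccccc1NC(=O)Nc1cc(C)nc2ccccc12` likewise ends at the limit with > 25000 nM. Compound 3 `Cc1cc(NC(=O)Nc2cnc3ccccc3c2)c2ccccc2n1` also returns the limit, > 25000 nM. All three values therefore sit at the limit of > 25000 nM in this assay, at which 3 of the 3 values shown sit, and compound 1 stands with the others, with no separation that can be read. Going by the values given here, no step between measured compounds is available. Compound 4 `Cc1cc(NC(=O)Nc2ccc(N)cc2)c2ccccc2n1` differs from compound 1 by amino in place of tert-butyl on an aromatic carbon. In this assay no step beyond the scatter is expected, and a result at the limit again seems most likely, as every measured value sits at the limit of > 25000 nM in this assay, at which 3 of the 3 values shown sit. The step is expected as a step that the limit leaves unreadable from compound 1 to compound 4. For compound 4 the expected value is 30000 nM, within 10000 nM to 100000 nM.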

Compound 4, half-maximal effective concentration: > 25000 nM
Compound 4: no number, only a limit; the forecaster's own chance of this, stated with the estimate: 80%; the middle value is on the limit's open side.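

No step can be read between compound 1 and compound 4, as both values are limits: the limit of > 25000 nM in this assay, at which 4 of the 4 values shown sit.

The compounds shown leave open whether amino in place of tert-butyl changes cytotoxicity, and at what concentration any of them would show an effect.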